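Urea in place of amide on the carbonyl of compound 1

This account rests on a few compounds, and the source may have more. Where it says the series, first, only, none or still open, it means among the compounds named here.

Compound 1 `COc1cc(-c2nn(-c3cccc(NC(=O)c4ccc(Cl)c(C(F)(F)F)c4)c3)cc2-c2ccncc2)ccc1Cl` gives no number in a functional assay on OVCAR-8 cells (Homo sapiens) for inhibition, read by sulforhodamine B assay, with a stated time of 48 h; a lower number here means a stronger inhibitor of growth, a higher number a weaker inhibitor of growth; its result is a limit of the assay, > 32500 nM. That limit, (the limit of > 32500 nM in this assay, at which 1 of the 2 values shown sits), is all that is known of compound 1, so its standing among the numbers shown cannot be fixed beyond it. Going by the values given here, compound 2 `O=C(Nc1cccc(-n2cc(-c3ccncc3)c(-c3ccc(Cl)c(O)c3)n2)c1)Nc1cc(C(F)(F)F)cc(C(F)(F)F)c1` is the only member with a measured concentration for total growth inhibition; in this assay compound 2 gives 5920 nM. Compound 3 `COc1cc(-c2nn(-c3cccc(NC(=O)Nc4ccc(Cl)c(Cl)c4)c3)cc2-c2ccncc2)ccc1Cl` is not yet measured and differs from compound 1 in one place: (3,4-dichlorophenyl)amino in place of 4-chloro-3-(trifluoromethyl)phenyl on a carbonyl carbon. Among the compounds with values here, no measured pair covers this change, so its size is open. Since compound 2 reaches a measurable value where compound 1 does not, the step from compound 1 to compound 3 is expected to run toward stronger inhibition, roughly an at least 4.0-fold lower number from compound 1 to compound 3 (0.60 log units; beyond the scatter). Compound 3 is estimated at 8000 nM, with a range from 2500 nM to 25000 nM.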

Compound 3, concentration for total growth inhibition: 3610 nM
For compound 3 the middle estimate is 2.2-fold (0.35 log units) above the measured one; the range from low to high includes it.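

In this assay, the carbonyl carbon whose other neighbours are amide-type nitrogen is a position where the group carried changes the reading: (3,4-dichlorophenyl)amino in place of 4-chloro-3-(trifluoromethyl)phenyl gives an at least 9.0-fold lower number from compound 1 to compound 3 (0.95 log units; beyond the scatter). Compound 1 stands at a limit of the assay, so the step gives a bound on the change and not its full size: the limit of > 32500 nM in this assay, at which 1 of the 3 values shown sits. The exchange brings in an amino nitrogen with a hydrogen-bond donor and also replaces the trifluoromethyl-bearing ring with a dichlorinated one, and this single step does not separate the two.

Still open, from the compounds shown here alone, is how much of the step belongs to the amino nitrogen and how much to the ring substituents. Also open, going by these compounds, is how a non-aromatic group such as piperidin-1-yl would read on the same carbonyl carbon.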